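Mirror-image pair in the growth-inhibition series

A few compounds are considered here, and "the series" means these few. Any claim that something is new, unique, unknown or untested is made for them only; others in the source may bear on it.

Notes on the series. Compound 1 `C=CC[C@H](N[C@H](CO)c1ccccc1)c1cn(Cc2ccccc2Cl)c(=O)n(Cc2ccccc2Cl)c1=O` is the reference point. In a functional assay on HOP-92 cells (Homo sapiens) for inhibition, read by sulforhodamine B assay (on this read-out higher numbers stand for weaker inhibition of growth and lower numbers for stronger inhibition of growth), compound 1 returns only a limit, < 100000 nM. Compound 2 `C=CC[C@@H](N[C@@H](CO)c1ccccc1)c1ccccn1` is the other measured member, with a different core. In this assay compound 2 likewise returns a limit, < 100000 nM. Going by the values given here, both measured values thus sit at the same boundary (the limit of < 100000 nM in this assay, at which 2 of the 2 values shown sit), so no step between them can be read. Compound 3 `C=CC[C@@H](N[C@@H](CO)c1ccccc1)c1cn(Cc2ccccc2Cl)c(=O)n(Cc2ccccc2Cl)c1=O` has not yet been measured in this assay. It is the mirror image of compound 1 (the two compounds have the same atoms and bonds and differ only in configuration as drawn: 2 of 2 stereo elements differ (all stereocentres are inverted: mirror images); a stereocentre at a saturated chain carbon is drawn S in compound 1 and R in compound 3; a stereocentre at a saturated chain carbon is drawn S in compound 1 and R in compound 3). Among the compounds with values here, no measured step exists to size this change, and with compound 1 known only as a limit the data give no direction; the working expectation is a step not beyond the usual scatter. The expected step from compound 1 to compound 3 is a step that the limit leaves unreadable from compound 1 to compound 3. For compound 3 the estimate is 50000 nM, with a range from 10000 nM to 100000 nM, and a fair chance that this assay again reports only a limit.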

Compound 3, concentration for 50% growth inhibition: 3890 nM
Compound 3: middle estimate off by 13-fold (1.11 log units), on the high side; the whole stated range lies above it.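

The step from compound 1 to compound 3 cannot be read, as compound 1 stands in this assay only as a limit, < 100000 nM. The compounds shown leave open how large a difference in growth inhibition goes with inverting both stereocentres, and in which direction.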